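The compounds below may be only part of what the source reports. "The series", "measured", "known", "first", "only" and "open" are said of these compounds alone.

Within the data shown here, compound 3 `C=CC(=O)Nc1cccc(-n2c(-c3nc(-c4cnn(C)c4)cnc3N)nc3ccccc32)c1` is one of three compounds measured in a physicochemical assay for solubility, at pH 7.4; on this read-out higher numbers stand for higher solubility and lower numbers for lower solubility. In this assay compound 3 reaches only the limit of < 10000 nM, and that is a boundary of the assay rather than a number. Compound 1 `C=CC(=O)Nc1ccc(F)c(-n2c(-c3nc(-c4cnn(C5CCN(C)CC5)c4)cnc3N)nc3ccccc32)c1` also returns the limit < 10000 nM. Compound 2 `C=CC(=O)Nc1cccc(-n2c(-c3nc(-c4cnn(C5CCN(C)CC5)c4)cnc3N)nc3ccccc32)c1F` likewise returns the limit < 10000 nM. Among the measured compounds shown here, the one step between compounds differing in a single place, a step that the two limits leave unreadable from compound 1 to compound 2, cannot be read because both of its ends sit at the same limit, as the limit of < 10000 nM in this assay, at which 3 of the 3 values shown sit, records. Compound 4 `C=CC(=O)Nc1cccc(-n2c(-c3nc(-c4cnn(C5CCN(CC)CC5)c4)cnc3N)nc3ccccc32)c1` is not yet measured; it differs from compound 3 by 1-ethylpiperidin-4-yl in place of methyl on an aromatic nitrogen. For the measured compounds named here, no measured step bears directly on this change, so the expectation rests on the fact that compounds 1 and 2, which carry a closely related substituent, also sit at the limit. Compound 4 is therefore expected to give 5000 nM, with a range from 1000 nM to 15000 nM. The expected step that the limit leaves unreadable from compound 3 to compound 4 is accordingly not one that can be resolved beyond the scatter.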

Compound 4, solubility: < 10000 nM
Compound 4: only a limit was reported; the forecaster's own chance of this, stated with the estimate: 70%; the middle value is on the limit's open side.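

In this assay no new step can be read between compound 3 and compound 4, since both stand at the same boundary of the assay: the limit of < 10000 nM in this assay, at which 4 of the 4 values shown sit. The compounds shown leave open how far any of them lies from that limit, and whether 1-ethylpiperidin-4-yl in place of methyl changes the read-out at all.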